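Cyclopropyl Chain to Pentan-3-yl on the Ring Nitrogen

A few compounds are considered here, and "the series" means these few. Any claim that something is new, unique, unknown or untested is made for them only; others in the source may bear on it.

Of the compounds shown here, three from one series have been measured in an assay for binding affinity to Corticotropin releasing factor receptor (Rattus norvegicus); on this read-out lower numbers stand for stronger inhibition and higher numbers for weaker inhibition. Compound 1 `CCCC(C)n1c(CC)nc2c(-c3ccc(S(C)(=O)=O)cc3C(F)(F)F)ccnc21` gives 6.8 nM in this assay. Compound 3 `CCCC(C)n1c(CC)nc2c(-c3ccc(C(F)(F)F)cc3Cl)ccnc21` gives 1.1 nM in this assay. Compound 2 `CCc1nc2c(-c3ccc(Cl)cc3Cl)ccnc2n1[C@@H](CC)C1CC1` gives 0.4 nM in this assay, the lowest of the three numbers; the closest to it is compound 3, whose number is higher by a margin beyond the usual scatter, and compound 1 lies further off, also beyond the scatter, so compound 2 is the most potent of the three. For the measured compounds named here, no two of the measured compounds differ in only one place, so no single step between them can be read off.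

Compound 4 `CCc1nc2c(-c3ccc(Cl)cc3Cl)ccnc2n1C(CC)CC` has not yet been measured. It differs from compound 2 in one place: pentan-3-yl in place of 1-cyclopropylpropyl on an aromatic nitrogen. Going by the values given here, nothing among the measured compounds shows what such a swap on this ring nitrogen does in this assay. The change is small, so a modest step is expected, if any, more likely towards a higher number than a lower one, and possibly none beyond the scatter. The expected step of a 2.0-fold higher number from compound 2 to compound 4 (0.30 log units; within the scatter) reflects that view. Compound 4 is estimated at 0.8 nM in this assay, with a range from 0.3 nM to 2.5 nM.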

Compound 4, inhibition constant: 1 nM
For compound 4 the middle estimate is 1.3-fold (0.10 log units) below the measured one; measured number inside the range.
By their numbers in this assay, from the lowest: compound 2; then compounds 4 and 3 (each within the scatter of the next); then compound 1.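

This change gives the series its first comparison in one place: in this assay, moving to pentan-3-yl on the aromatic nitrogen next to the ring atom that bears an ethyl group produces a 2.5-fold higher number from compound 2 to compound 4 (0.40 log units; beyond the scatter), with the rest of the structure held constant. The position therefore registers even this small swap, though the step is modest and compound 4 stays a potent binder on this read-out. The change removes the three-membered ring and the defined stereocentre and leaves one carbon fewer, and nothing measured here separates these differences or explains the step.

The compounds shown leave open which of those differences accounts for the step, a question that the opposite stereoisomer of compound 2, a cyclobutyl-bearing chain or a longer chain such as heptan-4-yl on the same nitrogen could help to settle. For the compounds shown here, they also leave open whether the step would carry over to the other aryl groups, such as the one in compound 3, since it has been read only with the aryl group shared by compound 2 and compound 4.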